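Aryl amide swap transferred to a second benzyl ether core

The source may hold more compounds than are shown below. What is called first, only, known or untested is meant among the compounds shown, and "the series" means these compounds.

Measured compounds:
compound 1: `COc1ccc(C(=O)Nc2ccc(N(C)S(C)(=O)=O)c(OCc3cc(Cl)ccc3Cl)c2)cc1OC` — 3730 nM
compound 2: `CN(c1ccc(NC(=O)c2ccc(I)cc2)cc1OCc1cc(Cl)ccc1Cl)S(C)(=O)=O` — 660 nM
compound 3: `COc1ccc(C(=O)Nc2ccc(N(C)S(C)(=O)=O)c(OCc3cc(C(F)(F)F)ccc3C)c2)cc1OC` — 16900 nM

The three compounds share an amide scaffold and were tested in a functional assay on SK-BR-3 cells (Homo sapiens) for antiproliferative activity, read by MTT assay, with a stated time of 48 h; a higher number here means a weaker inhibitor, a lower number a stronger inhibitor. Compound 1 gives 3730 nM, and compound 2, in the same assay, gives 660 nM. The difference between these two is 4-iodophenyl in place of 3,4-dimethoxyphenyl on a carbonyl carbon, and this change made a step of a 5.7-fold lower number from compound 1 to compound 2 (0.75 log units; beyond the scatter).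

Compound 3 carries a different core: it differs from compound 1 by 2-methyl-5-(trifluoromethyl)phenyl in place of 2,5-dichlorophenyl on a saturated chain carbon bound to an oxygen on an aromatic ring, and this change gave a step of a 4.5-fold higher number from compound 1 to compound 3 (0.66 log units; beyond the scatter), so that compound 3, with 16900 nM, has the highest number of the three.

Compound 4, `Cc1ccc(C(F)(F)F)cc1COc1cc(NC(=O)c2ccc(I)cc2)ccc1N(C)S(C)(=O)=O`, is not yet measured. It stands to compound 3 as compound 2 stands to compound 1: the difference is 4-iodophenyl in place of 3,4-dimethoxyphenyl on a carbonyl carbon, at the same place, on a carbonyl carbon whose other neighbours are an amide-type nitrogen, so this is the same change seen once before. This change has been observed only one time, from compound 1 to compound 2, so the expectation rests on a single step on a different core.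

The account therefore expects compound 4 to show a step of a 5.6-fold lower number from compound 3 to compound 4 (0.75 log units; beyond the scatter), of about the size seen once before, because a 5.7-fold lower number from compound 1 to compound 2 (0.75 log units; beyond the scatter) arose from the same change at the same place. The estimated value for compound 4 in this assay is 3000 nM, with an expected range from 1100 nM to 8500 nM.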

Compound 4, half-maximal inhibitory concentration: 3500 nM
Compound 4: the middle estimate sits 1.2-fold (0.07 log units) below what was measured; the measured number falls inside the stated range.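

In this assay, placing 4-iodophenyl in place of 3,4-dimethoxyphenyl on the carbonyl carbon gave a 4.8-fold lower number from compound 3 to compound 4 (0.68 log units; beyond the scatter), and this step agrees with the one seen earlier on the other core: the same change on two cores in this assay, a 5.7-fold lower number (0.75 log units; beyond the scatter) from compound 1 to compound 2 and a 4.8-fold lower number (0.68 log units; beyond the scatter) from compound 3 to compound 4, 1.2-fold (0.07 log units) apart, within the scatter of two such steps. The second change, 2-methyl-5-(trifluoromethyl)phenyl in place of 2,5-dichlorophenyl, gave a 5.3-fold higher number from compound 2 to compound 4 (0.72 log units; beyond the scatter) with 4-iodophenyl on the carbonyl carbon, and it too kept its size when the group on the carbonyl carbon was different: the same change on two cores in this assay, a 4.5-fold higher number (0.66 log units; beyond the scatter) from compound 1 to compound 3 and a 5.3-fold higher number (0.72 log units; beyond the scatter) from compound 2 to compound 4, 1.2-fold (0.07 log units) apart, within the scatter of two such steps. Across these four compounds, each change therefore carried over from one core to the other with its size intact, but this rests on a single pair of groups at each place in one cell assay, and it shows neither that other changes would carry over in the same way nor why these two did.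

As far as these compounds go, it remains open whether a 4-bromophenyl, or a phenyl ring bearing an amine or a carboxylic acid, would follow the same pattern on the carbonyl carbon. From the compounds shown here alone, it is also open whether the step from 3,4-dimethoxyphenyl to 4-iodophenyl would keep its size with a plain phenyl or a 2,5-dimethoxyphenyl on the saturated chain carbon.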